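Urea aryl exchange carried onto a trifluoromethyl core

The compounds below may be only part of what the source reports. "The series", "measured", "known", "first", "only" and "open" are said of these compounds alone.

Measured so far in a functional assay on MCF7 cells (Homo sapiens) for cytotoxicity, read by MTT assay, with a stated time of 24 h; a lower number here means a stronger inhibitor, a higher number a weaker inhibitor:
compound 1 `CCNc1cc(-c2ccc(NC(=O)Nc3cccc(Cl)c3)cc2C)ccn1` gives 4180 nM
compound 2 `CCNc1cc(-c2ccc(NC(=O)Nc3ccc(OC)cc3)cc2C)ccn1` gives 9950 nM
compound 3 `CCNc1cc(-c2ccc(NC(=O)Nc3cccc(Cl)c3)cc2C(F)(F)F)ccn1` gives 1240 nM

Compound 2 differs from compound 1 by 4-methoxyphenyl in place of 3-chlorophenyl on an amide-type nitrogen, a change that gave a 2.4-fold higher number from compound 1 to compound 2 (0.38 log units; beyond the scatter). Compound 3 differs from compound 1 by trifluoromethyl in place of methyl on an aromatic carbon, a step of a 3.4-fold lower number from compound 1 to compound 3 (0.53 log units; beyond the scatter), and compound 3 holds the lowest number of the three. Compound 4 `CCNc1cc(-c2ccc(NC(=O)Nc3ccc(OC)cc3)cc2C(F)(F)F)ccn1` has not yet been measured. It differs from compound 3 by 4-methoxyphenyl in place of 3-chlorophenyl on an amide-type nitrogen, the same change as between compound 1 and compound 2, now made on the core of compound 3. Compound 4 is expected to take a step of a 2.4-fold higher number from compound 3 to compound 4 (0.38 log units; beyond the scatter) because the same change gave a 2.4-fold higher number from compound 1 to compound 2 (0.38 log units; beyond the scatter). Compound 4 is therefore estimated in this assay at 3000 nM, with an expected range from 1500 nM to 6500 nM.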

Compound 4, half-maximal inhibitory concentration: 5740 nM
Compound 4: the middle estimate sits 1.9-fold (0.28 log units) below what was measured; measured number inside the range.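

In this assay, 4-methoxyphenyl in place of 3-chlorophenyl gave a 4.6-fold higher number from compound 3 to compound 4 (0.67 log units; beyond the scatter), a step in the same direction as on the core of compound 1 and not distinguishable from it in size: the same change on two cores in this assay, a 2.4-fold higher number (0.38 log units; beyond the scatter) from compound 1 to compound 2 and a 4.6-fold higher number (0.67 log units; beyond the scatter) from compound 3 to compound 4, 1.9-fold (0.29 log units) apart, within the scatter of two such steps

Trifluoromethyl in place of methyl, carried onto the 4-methoxyphenyl pair, gave a 1.7-fold lower number from compound 2 to compound 4 (0.24 log units; within the scatter), and this step too cannot be told apart in size from the earlier one: the same change on two cores in this assay, a 3.4-fold lower number (0.53 log units; beyond the scatter) from compound 1 to compound 3 and a 1.7-fold lower number (0.24 log units; within the scatter) from compound 2 to compound 4, 1.9-fold (0.29 log units) apart, within the scatter of two such steps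

So the aryl exchange carried over between these two cores, but the trifluoromethyl step was not confirmed beyond the scatter on the second pair, and four compounds establish no general rule.

The compounds shown leave open whether this holds for other groups in place of 3-chlorophenyl, such as cyclohexyl or a 4-cyanophenyl. They also leave open a longer chain in place of the ethyl on the amine.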